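The compounds below may be only part of what the source reports. "The series", "measured", "known", "first", "only" and "open" are said of these compounds alone.

Three compounds have been measured in a functional assay on HCT-15 cells (Homo sapiens) for cytotoxicity, read by CCK-8 assay and cell counting, with a stated time of 2 days; on this read-out higher numbers stand for weaker inhibition and lower numbers for stronger inhibition:

Compound 1 `Oc1ccc(-c2cc(-c3ccsc3)nc(-c3cccc(Cl)c3)c2)cc1` gives 5760 nM.
Compound 2 `Oc1cccc(-c2cc(-c3ccc(Cl)cc3)nc(-c3ccsc3)c2)c1` gives 8850 nM.
Compound 3 `Oc1ccc(-c2cc(-c3ccc(Cl)cc3)nc(-c3cccs3)c2)cc1` gives 6470 nM.

Compound 3 stands second highest of these three numbers; its nearest neighbour is compound 1 and its furthest is compound 2, and both gaps lie within the scatter of this kind of measurement. Compound 4 `Oc1ccc(-c2cc(-c3ccc(Cl)cc3)nc(-c3ccsc3)c2)cc1` has the same atoms as compound 3, joined differently: thiophen-3-yl in place of thiophen-2-yl on an aromatic carbon. Compound 1 and compound 2 already carry a thiophen-3-yl group, and neither of their values stands apart from compound 3 beyond the scatter, so in this assay no step beyond the scatter is expected here. The expected step is a 1.0-fold higher number from compound 3 to compound 4 (0.00 log units; within the scatter). Compound 4 is estimated at 6500 nM, with a range from 3500 nM to 12000 nM.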

Compound 4, half-maximal inhibitory concentration: 6240 nM
The estimate for compound 4 lay 1.0-fold (0.02 log units) above the measured number, and the stated range covers the measured number.
By their numbers in this assay, from the lowest: compounds 1, 4, 3 and 2 (each within the scatter of the next).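

In this assay, going by these compounds alone, thiophen-3-yl in place of thiophen-2-yl next to the ring nitrogen gives a 1.0-fold lower number from compound 3 to compound 4 (0.02 log units; within the scatter) and so provides the first direct reading of this change. Within the data shown here, compound 4 also connects the earlier compounds: 4-hydroxyphenyl in place of 3-hydroxyphenyl gives a 1.4-fold lower number from compound 2 to compound 4 (0.15 log units; within the scatter) while 4-chlorophenyl in place of 3-chlorophenyl gives a 1.1-fold higher number from compound 1 to compound 4 (0.03 log units; within the scatter) and all three single changes stay within the scatter. Nothing measured here speaks to what underlies these values. The compounds shown leave open whether an amine or a carboxylic acid in place of the thiophenyl group would shift the number beyond the scatter.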